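The source may report more compounds than this note shows. Statements on the series, on what has been measured and on what is new or still open speak of the compounds shown alone.

Measured in an ADME assay on microsomes from liver (Mus musculus) for metabolic stability, tested at 5 uM; on this read-out higher numbers stand for a longer-lived compound and lower numbers for a shorter-lived compound:

- Compound 1 `CCCCCCNc1ccc([N+](=O)[O-])cc1S(N)(=O)=O` gives < 0.0834 h as a limit
- Compound 2 `O=C(O)c1ccc(NCCCCCCCC(F)(F)F)c(S(=O)(=O)N2CCCC2)c1` gives > 1 h as a limit
- Compound 3 `O=C(O)c1ccc(NCCCCCCCC(F)(F)F)c(S(=O)(=O)N2CCOCC2)c1` gives > 1 h as a limit

None of these three results is an exact number. Compound 3 stands at the limit of > 1 h in this assay, at which 2 of the 3 values shown sit, and that is a limit.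

Compound 4 `O=C(O)c1ccc(NCCCCCCCC(F)(F)F)c(S(=O)(=O)NC2CCOCC2)c1` differs from compound 3 by (oxan-4-yl)amino in place of morpholin-4-yl on a sulfonyl sulfur, a change counted as (oxan-4-yl)amino in place of morpholin-4-yl on a sulfonyl sulfur. Among the compounds with values here, the only measured change at this place is a step that the two limits leave unreadable from compound 2 to compound 3, with morpholin-4-yl in place of pyrrolidin-1-yl, so it offers no size to carry over.

Compound 1 stands at the limit of < 0.0834 h in this assay, at which 1 of the 3 values shown sits. Within the data shown here, it differs from compound 3 in more than one place and so sets no size for this step.

Among the measured compounds shown here, since a step that the two limits leave unreadable from compound 2 to compound 3 is the only measured evidence at this place, no step beyond the usual scatter is expected in this assay, in either direction. The estimated change is a step that the limit leaves unreadable from compound 3 to compound 4, and a report as a limit alone would be no surprise. For compound 4 the expected value is 1.2 h, with an estimated range from 0.5 h to 3 h.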

Compound 4, half-life: > 1 h
Compound 4: no number, only a limit; the forecaster's own chance of this, stated with the estimate: 70%; the middle value does not contradict the limit.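

In this assay compound 4 gives > 1 h, which is a limit. Compound 2 and compound 3 also give only limits, so no step among these three compounds can be read. As far as these compounds go, the actual half-life of each, and whether the group on the sulfonyl sulfur changes it, stays open.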